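The compounds below may be only part of what the source reports. "The series", "measured", "known", "first", "only" and "open" are said of these compounds alone.

Compound 1 `COc1ccc([C@H]2CC(=O)N(c3cccnc3)C2)cc1OC1CCCC1` and compound 2 `COc1ccc([C@H]2CC(=O)N(c3cccc([S+](C)[O-])c3)C2)cc1OC1CCCC1` share one core and differ only in the group on the amide-type nitrogen in the ring. In a functional assay on HEK293 cells (Homo sapiens) for cytotoxicity (a lower number here means that less compound is tolerated, a higher number that more compound is tolerated), compound 1 gives no number but a limit, > 10000 nM. In this assay compound 2 also gives only a limit, > 10000 nM. The step that the two limits leave unreadable from compound 1 to compound 2 therefore cannot be sized, which is what the limit of > 10000 nM in this assay, at which 2 of the 2 values shown sit, states. Within the data shown here, compound 2 thus stands at the limit of this assay, and the one other value shown sits at the same limit.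

Compound 3 `COc1ccc([C@H]2CC(=O)N(c3cccc(NS(=O)(=O)c4cccc(Cl)c4C)c3)C2)cc1OC1CCCC1` has not yet been measured. It differs from compound 2 by a group of 12 heavy atoms (7 carbon, 1 nitrogen, 2 oxygen, 1 sulfur, 1 chlorine; one six-membered aromatic ring of carbon only) in place of a group of 3 heavy atoms (1 carbon, 1 oxygen, 1 sulfur; no ring), on an aromatic carbon. The only measured step, the one from compound 1 to compound 2, touches a different place of the core and gives no readable size, so nothing shown points to a direction for the change in compound 3. Compound 3 is therefore expected to stay near the limit of this assay, with an estimate of 12000 nM and a range from 4000 nM to 40000 nM. The step that the limit leaves unreadable from compound 2 to compound 3 that this estimate implies is expected to lie within the scatter, though the larger entering group leaves this open.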

Compound 3, half-maximal cytotoxic concentration: > 10000 nM
Compound 3: no number, only a limit; the forecaster's own chance of this, stated with the estimate: 65%; the middle value lies beyond the limit too.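

In this assay compound 3 gives only a limit (> 10000 nM), so the step from compound 2 to compound 3 cannot be read. The compounds shown leave open how compound 1, compound 2 and compound 3 rank against one another, and whether any change on the shared core would bring a readable number: the limit of > 10000 nM in this assay, at which 3 of the 3 values shown sit.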